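The source may report more compounds than this note shows. Statements on the series, on what has been measured and on what is new or still open speak of the compounds shown alone.

Working notes on the series. Two compounds sharing the trimethoxyphenyl motif have been run in a functional assay on BGC-823 cells (Homo sapiens) for antiproliferative activity, read by MTT assay, tested at 1 uM; a lower number here means a weaker effect, a higher number a stronger effect of the compound at the concentration tested. Compound 1 `COc1cc(C2=NN(C(C)=O)C(c3c(Cl)cccc3Cl)O2)cc(OC)c1OC` gives -1.4% in this assay, and compound 2 `COc1cccc(/C=N/NC(=O)c2cc(OC)c(OC)c(OC)c2)c1OC` gives -0.1%. Compound 1 stands at the lower end of these two numbers, but the gap to compound 2 lies within the usual scatter, so neither compound shows any effect at the concentration tested and nothing separates them.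

Compound 3 `COc1cc(C2=NN(C(C)=O)C(c3ccc(Cl)c(Cl)c3)O2)cc(OC)c1OC` has not yet been measured. Relative to compound 1 it carries 3,4-dichlorophenyl in place of 2,6-dichlorophenyl on a saturated ring carbon. Going by the values given here, the two compounds keep the same atoms, joined differently, and no step between measured compounds is available to say how moving the two chlorines around the ring bears on this assay.

Given that compound 1 sits at -1.4% and compound 2 at -0.1%, no step beyond the scatter is expected from compound 1 to compound 3, in either direction, with a step of a number 3.4 percentage points higher from compound 1 to compound 3 (within the scatter). Compound 3 is therefore estimated at 2% in this assay, in a range from -9% to 16%.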

Compound 3, a percentage reported as inhibition, at one concentration (the size of the read-out at that concentration, not a potency): -0.8%
The estimate for compound 3 lay 2.8 percentage points above the measured number, within the range that was stated.
By their numbers in this assay, from the lowest: compounds 1, 3 and 2 (each within the scatter of the next).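

Placing 3,4-dichlorophenyl in place of 2,6-dichlorophenyl on the saturated ring carbon gives the only step that can be read at this position so far: in this assay the change is a number 0.6 percentage points higher from compound 1 to compound 3 (within the scatter) and lies within the scatter. The two compounds have the same atoms joined differently, so at this position and at the concentration tested, the placement of the two chlorines on the phenyl ring does not separate compound 1 from compound 3. Neither arrangement gives a detectable effect in this read-out, and no independent data bear on why the two arrangements read alike.

On these data alone, it remains open whether any group on this saturated ring carbon can lift the reading beyond the scatter, for instance a phenyl ring carrying an amine or a carboxylic acid instead of the chlorines, or a longer chain in place of the dichlorophenyl group. As far as these compounds go, it is also open whether replacing the acetyl group on the ring nitrogen would change the reading, and whether these compounds stay without effect at higher concentrations.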